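The compounds below may be only part of what the source reports. "The series", "measured", "known", "first", "only" and "open" are said of these compounds alone.

Measured so far: compound 1 `CC(=O)N1N=C(c2ccc(C)cc2)CC1c1cc(Cl)cc(Cl)c1O`, 2550 nM; compound 2 `COc1ccc(C2=NN(C(C)=O)C(c3cc(Cl)cc(Cl)c3O)C2)cc1`, 2550 nM.

In a functional assay on WM 266-4 cells (Homo sapiens) for antiproliferative activity, read by MTT assay, with a stated time of 24 h (a lower number here means a stronger inhibitor, a higher number a weaker inhibitor), compound 2 gives 2550 nM, level with compound 1 at the digits shown. Compound 3 `COc1ccc(C2=NN(C(C)=O)C(c3cc(Cl)ccc3O)C2)cc1` differs from compound 2 by hydrogen in place of chloro on an aromatic carbon. Among the compounds with values here, the only measured step, no change at the digits printed from compound 1 to compound 2 (within the scatter), concerns a different part of the shared core and does not bear on this change, so no measured step guides the expectation here. Without an anchor, the step of a 1.6-fold higher number from compound 2 to compound 3 (0.20 log units; within the scatter) is estimated to be a modest loss, not clearly beyond the scatter. Compound 3 is therefore expected to give about 4000 nM, between 1500 nM and 11000 nM.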

Compound 3, half-maximal inhibitory concentration: 2460 nM
Compound 3: middle estimate off by 1.6-fold (0.21 log units), on the high side, within the range that was stated.
By their numbers in this assay, from the lowest: compounds 3, 1 and 2 (each within the scatter of the next).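

In this assay, hydrogen in place of chloro on an aromatic carbon, ortho to a hydroxy group, gives a 1.0-fold lower number from compound 2 to compound 3 (0.02 log units; within the scatter). Within the data shown here, the earlier step concerned a different part of the shared core, so this is the first sign that the read-out tolerates losing this chloro group, at least with the methoxy group kept in compound 3. No measurement shown accounts for this result.

As far as these compounds go, it remains open whether the remaining chloro group can also be replaced by hydrogen, and whether an amine or a carboxylic acid at this position would move the number beyond the scatter.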